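Trimming one methoxy group from compound 2

A few compounds are considered here, and "the series" means these few. Any claim that something is new, unique, unknown or untested is made for them only; others in the source may bear on it.

Compound 1 `COc1cc(OC)c(OC)cc1/C=C/COC(=O)/C=C/c1ccc(OC)c(OC)c1` and compound 2 `COc1cc(OC)c(OC)cc1/C=C/COC(=O)/C=C/c1cc(OC)c(OC)c(OC)c1OC` were both examined in a functional assay on the whole organism (strain Kunming) with Mus musculus as the target, with a stated time of 0.5 h, at a dose of 300 mg/kg by the intraperitoneal route; on this read-out higher numbers stand for a weaker effect at the one dose given and lower numbers for a stronger effect. There compound 1 gives 0%, and compound 2 gives 0%, level with compound 1 within the scatter. Compound 3 `COc1cc(OC)c(OC)cc1/C=C/COC(=O)/C=C/c1cc(OC)c(OC)c(OC)c1` differs from compound 2 by hydrogen in place of methoxy on an aromatic carbon. Going by the values given here, the measured pair offers no single-change step in this assay to lean on, and since both compounds already sit at the bottom of the read-out, no step beyond the scatter is expected here. The expected step of no change at the digits printed from compound 2 to compound 3 (within the scatter) therefore amounts to nothing beyond the scatter. Compound 3 is estimated to give 0%, between 0% and 15%.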

Compound 3, a percentage reported as activity, at one dose (the size of the read-out at that dose, not a potency): 25%
The estimate for compound 3 lay 25 percentage points below the measured number, and the stated range ends below it.
By their numbers in this assay, from the lowest: compounds 1 and 2 (each within the scatter of the next); then compound 3.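

In this assay the methoxy on the aromatic carbon ortho to a large group counts: hydrogen in its place gives a number 25 percentage points higher from compound 2 to compound 3 (beyond the scatter), which on this read-out means a weaker effect at the one dose given. The opposite kind of change, methoxy in place of hydrogen on an aromatic carbon, gives a number 25 percentage points higher from compound 1 to compound 3 (beyond the scatter), so removing and adding a methoxy both lead to compound 3 with a higher number, and which carbon changes matters. Nothing available explains either step. Going by these compounds, whether a hydroxyl, a fluorine or an amine on this carbon would behave like the methoxy or like the hydrogen stays open.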